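The compounds below may be only part of what the source reports. "The series", "measured", "known", "first", "only" and "open" are said of these compounds alone.

Compound 1 `CN1C(=O)N(C)C2C1NC(=S)N2/N=C/C=C/c1ccccc1` and compound 3 `CCN1C(=O)N(CC)C2C1NC(=S)N2/N=C/C=C/c1ccccc1` are built on closely related frameworks, but the difference between the two cores is not broken down here. Among the compounds with values here, in a functional assay on RD cells (Homo sapiens) for inhibition, read by MTT assay, with a stated time of 72 h (a lower number here means a stronger inhibitor, a higher number a weaker inhibitor), compound 1 gives 46000 nM, while compound 3 gives 2250 nM, the lowest of the three numbers measured so far; compound 3 sits apart from compound 1 by a gap that lies beyond the usual scatter. Compound 2 `CC(/C=N/N1C(=S)NC2C1N(C)C(=O)N2C)=C\c1ccccc1` is compound 1 altered in a single place, (methyl in place of hydrogen on a double-bonded chain carbon bound to a carbon with a double bond to nitrogen and a double-bonded chain carbon), and in this assay compound 2 gives 84000 nM. The step is a 1.8-fold higher number from compound 1 to compound 2 (0.26 log units; within the scatter), so the two numbers cannot be told apart with confidence.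

Compound 4 `CCN1C(=O)N(CC)C2C1NC(=S)N2/N=C/C(C)=C/c1ccccc1` carries exactly this change on the core of compound 3: methyl in place of hydrogen on a double-bonded chain carbon bound to a carbon with a double bond to nitrogen and a double-bonded chain carbon. The position words are the same in both cases, so it is the same change made on the other core, and this is its only other occurrence among the compounds shown.

Because the earlier instance of the change gave a 1.8-fold higher number from compound 1 to compound 2 (0.26 log units; within the scatter), compound 4 is expected to give about 3500 nM in this assay, most likely somewhere from 1200 nM to 12000 nM. This estimate amounts to an expected step of a 1.6-fold higher number from compound 3 to compound 4 (0.19 log units; within the scatter), a size that rests only on the near-equal numbers seen when the change was made the first time.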

Compound 4, half-maximal inhibitory concentration: 20000 nM
Compound 4: middle estimate off by 5.7-fold (0.76 log units), on the low side; the whole stated range lies below it.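

In this assay, methyl in place of hydrogen on the double-bonded chain carbon gives an 8.9-fold higher number from compound 3 to compound 4 (0.95 log units; beyond the scatter), so on this core the change clearly weakens inhibition. Set beside its earlier instance, the size of the step does not carry over unchanged from one core to the other: the same change on two cores in this assay, a 1.8-fold higher number (0.26 log units; within the scatter) from compound 1 to compound 2 and an 8.9-fold higher number (0.95 log units; beyond the scatter) from compound 3 to compound 4, 4.9-fold (0.69 log units) apart, beyond the scatter of two such steps. This shows that, in these two pairs, the result of the change depends on the core that carries it, but two pairs give no rule for any other core; they do not show which feature of the cores is responsible, and, with the earlier step within the scatter, they do not establish that the change acts in the same direction on both.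

The compounds shown leave open how an ethyl group, a longer chain, a chlorine atom or a hydroxyl group would behave in place of this methyl on either core. They also leave open whether the same change on a core carrying propyl groups in place of the ethyl groups of compound 3 would give a step closer to the larger or the smaller of the two seen here.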